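Cyclopropyl to methyl on the shared core

The compounds below may be only part of what the source reports. "The series", "measured", "known", "first", "only" and "open" are said of these compounds alone.

Values so far in an in vitro ADME assay on microsomes from liver (Simiiformes); a higher number here means that the compound lasts longer, a lower number that the compound disappears faster 
Compound 1 `COCc1cc(CCCOc2c(C)cc(-c3noc(C(F)(F)F)n3)cc2C)on1` gives 1.58 h 
Compound 2 `COCc1cc(CCCOc2c(C)cc(-c3noc(C4CC4)n3)cc2C)on1` gives > 2.5 h as a limit, not a number 
Compound 3 `COCc1cc(CCCOc2c(C)cc(-c3noc(C)n3)cc2C)on1` is not yet measured

Compound 2 stands at > 2.5 h as a limit of the assay, not a number. What the data offer here is the limit of > 2.5 h in this assay, at which 1 of the 2 values shown sits, and no exact half-life. Compound 3 differs from compound 2 by a single change, methyl in place of cyclopropyl on an aromatic carbon in short, methyl in place of cyclopropyl on an aromatic carbon. Among the compounds with values here, one measured step bears on this carbon, an at least 1.5-fold higher number from compound 1 to compound 2 (0.19 log units; that floor lies within the scatter) when cyclopropyl replaced trifluoromethyl. Its floor lies within the scatter, and methyl was not part of it, so it gives only a weak guide. The expected size is an at least 1.0-fold lower number from compound 2 to compound 3 (0.03 log units; that floor lies within the scatter) as an estimate, with no change beyond the scatter expected. Compound 3 is estimated at 2.3 h in this assay with an expected range from 1.2 h to 4 h around that figure.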

Compound 3, half-life: 0.5 h
The estimate for compound 3 lay 4.6-fold (0.66 log units) above the measured number, outside the stated range (below it).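

In this assay, the group on this aromatic carbon makes a clear difference, which the earlier pair of compounds could not establish: methyl in place of cyclopropyl gives an at least 5.0-fold lower number from compound 2 to compound 3 (0.69 log units; beyond the scatter). Methyl in place of trifluoromethyl gives a 3.2-fold lower number from compound 1 to compound 3 (0.50 log units; beyond the scatter), so among these three groups methyl gives the lowest number, with both steps beyond the scatter. The first step is only a floor, since compound 2 has a limit and not an exact half-life: the limit of > 2.5 h in this assay, at which 1 of the 3 values shown sits.

The compounds shown do not explain why methyl stands lowest, and the true gap between cyclopropyl and trifluoromethyl remains unresolved. From the compounds shown here alone, it also remains open whether an ethyl group or an amine on this carbon would give a number close to that of methyl or close to those of the other two groups.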